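A few compounds are considered here, and "the series" means these few. Any claim that something is new, unique, unknown or untested is made for them only; others in the source may bear on it.

Compound 1, `COc1ccc2[nH]cc(C(=O)/C(C#N)=C/C=C(\Cl)c3ccc(OC)c(OC)c3)c2c1`: 74.2%
Compound 2, `COc1ccc(/C(Cl)=C/C=C(\C#N)C(=O)c2c[nH]c3ccccc23)cc1`: 76.9%

In a functional assay for inhibition, read by Griess assay, with a stated time of 150 min, tested at 1 mM (on this read-out higher numbers stand for more inhibition at the one concentration tested (going by the name of the read-out) and lower numbers for less inhibition), compound 2 gives 76.9% and compound 1 gives 74.2%; the two numbers lie within the usual scatter of each other, so neither compound stands apart. Compound 3, `COc1ccc(/C(Cl)=C/C=C(\C#N)C(=O)c2c[nH]c3ccccc23)cc1OC`, differs from compound 2 in one place: methoxy in place of hydrogen on an aromatic carbon. Among the measured compounds shown here, no measured pair isolates this change. Since both measured compounds carry methoxy groups yet land close together, the step in this assay is expected to stay within the scatter, with no clear direction, giving an expected a number 0.9 percentage points lower from compound 2 to compound 3 (within the scatter). Compound 3 is therefore estimated at 76%, with a range from 64% to 86%.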

Compound 3, a percentage reported as inhibition, at one concentration (the size of the read-out at that concentration, not a potency): 75%
Compound 3: the middle estimate sits 1 percentage points above what was measured; the range from low to high includes it.
By their numbers in this assay, from the lowest: compounds 1, 3 and 2 (each within the scatter of the next).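

In this assay, adding methoxy to the six-membered aromatic ring, ortho to a methoxy group and meta to a large group, gives a number 1.9 percentage points lower from compound 2 to compound 3 (within the scatter), so this change alone does not separate the two compounds. A second single change, hydrogen in place of methoxy on an aromatic carbon, gives a number 0.8 percentage points higher from compound 1 to compound 3 (within the scatter), which also does not separate its pair. No independent evidence bears on this result.

On these data alone, whether an amine or a carboxylic acid at this position would give a value beyond the scatter remains open. As far as these compounds go, with only one concentration, any difference in potency also remains open.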